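Reversed Enone Linker and Methyl for Chlorine on a Shared Core

The source may report more compounds than this note shows. Statements on the series, on what has been measured and on what is new or still open speak of the compounds shown alone.

The compounds measured so far, with their values:
compound 1 `COc1cc(-c2cc(C(=O)/C=C/c3ccc(Cl)cc3)nc3cc(-c4ccccc4)nn23)cc(OC)c1OC` gives 21600 nM in a functional assay on MDA-MB-231 cells (Homo sapiens) for antiproliferative activity, read by MTT assay, with a stated time of 24 h; a higher number here means a weaker inhibitor, a lower number a stronger inhibitor;
compound 2 `COc1ccc(-c2cc(C(=O)/C=C/c3ccc(Cl)cc3)nc3cc(-c4ccccc4)nn23)cc1OC` gives 23700 nM in this assay;
compound 3 `COc1ccc(-c2cc(/C=C/C(=O)c3ccc(OC)c(OC)c3)nc3cc(-c4ccccc4)nn23)cc1` gives 8700 nM in this assay.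

Compound 1 stands second highest of the three numbers. Its nearest neighbour is compound 2, with a 1.1-fold higher number from compound 1 to compound 2 (0.04 log units; within the scatter), so these two are not distinguished. Compound 3, with the enone running the other way and dimethoxyphenyl groups at both ends, sits furthest from compound 1 at a lower number, a gap beyond the scatter.

Compound 4 `COc1cc(-c2cc(/C=C/C(=O)c3ccc(C)cc3)nc3cc(-c4ccccc4)nn23)cc(OC)c1OC` differs from compound 1 in one place: 2-((4-methylphenyl)carbonyl)ethenyl in place of (2-(4-chlorophenyl)ethenyl)carbonyl on an aromatic carbon. The only measured step is the methoxy-to-hydrogen change from compound 1 to compound 2, and it does not touch the enone or its aryl end, so no listed step bears directly on this change. The pair of compound 1 and compound 3 shows that a reversed enone carrying a different aryl group gave a lower number, but two features change together there.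

The expected step from compound 1 to compound 4 is therefore a modest lowering, a 1.8-fold lower number from compound 1 to compound 4 (0.26 log units; within the scatter), with wide uncertainty. Compound 4 is estimated at 12000 nM, between 4000 nM and 36000 nM.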

Compound 4, half-maximal inhibitory concentration: 23900 nM
The estimate for compound 4 lay 2.0-fold (0.30 log units) below the measured number; the range from low to high includes it.
By their numbers in this assay, from the lowest: compound 3; then compounds 1, 2 and 4 (each within the scatter of the next).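

In this assay, exchanging the (2-(4-chlorophenyl)ethenyl)carbonyl group for 2-((4-methylphenyl)carbonyl)ethenyl gives a 1.1-fold higher number from compound 1 to compound 4 (0.04 log units; within the scatter) and so does not separate the two compounds. Within the data shown here, this is the first measured single-place step at this position, on the aromatic carbon next to the ring nitrogen, and it shows that with the 3,4,5-trimethoxyphenyl group held constant, this replacement of the whole side chain, with its reversed enone and methyl in place of chlorine, leaves the antiproliferative reading within the scatter. No measured evidence is available here to explain this result.

Going by these compounds, whether the reversal of the enone and the exchange of chlorine for methyl would each leave the reading within the scatter on their own stays open, as the step carries both at once and a similar overall reading could hide opposing contributions. Also open, on these data alone, is how this position would read in this assay with an amine or a carboxylic acid in place of the methyl on the far aromatic ring, or with a longer chain in place of the enone.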